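Two methoxy groups in place of one on the phenyl ring

A few compounds are considered here, and "the series" means these few. Any claim that something is new, unique, unknown or untested is made for them only; others in the source may bear on it.

Of the compounds shown here, three share a core and have been measured in a functional assay, with a stated time of 10 min; a higher number here means a weaker inhibitor, a lower number a stronger inhibitor. Compound 1 `CCOC(=O)c1cnn(-c2nc(-c3ccc(OC)cc3)c(C#N)c(=O)n2C)c1N` gives 74 ug/mL. Compound 2 `CSc1nc(-c2ccccc2O)c(C#N)c(=O)n1C` gives 39 ug/mL, and compound 3 `CSc1nc(-c2cccc(O)c2O)c(C#N)c(=O)n1C` gives 37 ug/mL. All three numbers lie within the usual scatter of one another, so no order among them can be claimed. Among the measured compounds shown here, the only single-point step among the measured compounds is a 1.1-fold lower number from compound 2 to compound 3 (0.02 log units; within the scatter), a hydroxy added to the phenyl ring that left the number essentially unchanged.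

Compound 4 `CCOC(=O)c1cnn(-c2nc(-c3cccc(OC)c3OC)c(C#N)c(=O)n2C)c1N` differs from compound 1 by 2,3-dimethoxyphenyl in place of 4-methoxyphenyl on an aromatic carbon. For the measured compounds named here, the one measured step that adds a group to the phenyl ring stayed within the scatter, and nothing among the measured compounds tests a second methoxy or a shift of its position. The step of a 1.1-fold lower number from compound 1 to compound 4 (0.02 log units; within the scatter) is therefore expected to stay within the scatter, in no clear direction. Compound 4 is expected to give 70 ug/mL, with a range from 30 ug/mL to 160 ug/mL.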

Compound 4, half-maximal inhibitory concentration: 67 ug/mL
The estimate for compound 4 lay 1.0-fold (0.02 log units) above the measured number; low and high end bracket the measured number.
By their numbers in this assay, from the lowest: compounds 3, 2, 4 and 1 (each within the scatter of the next).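

In this assay, 2,3-dimethoxyphenyl in place of 4-methoxyphenyl gives a 1.1-fold lower number from compound 1 to compound 4 (0.04 log units; within the scatter) and so stays within the scatter. This is the only step shown at this position on the core of compound 1, and it shows that a second methoxy and a changed placement, taken together, produce no readable shift in the number, something compounds 1, 2 and 3 alone did not test. No data at hand bear on this result.

Both alterations arrive in a single step, so the compounds shown cannot tell whether each alone would also stay within the scatter or whether the two offset each other. Going by these compounds, it also remains open whether a different kind of group on the phenyl ring, such as an amine or a carboxylic acid, would move the number beyond the scatter.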